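A few compounds are considered here, and "the series" means these few. Any claim that something is new, unique, unknown or untested is made for them only; others in the source may bear on it.

Working notes on the series:

- compound 1 `COc1ccc(C2C=C(c3cc(OC)c(OC)c(OC)c3)NC(=S)N2)cc1`: 90 nM
- compound 2 `COc1cccc(C2=NN(c3ccccc3)C(c3ccc(Br)cc3)C2O)c1`: 9.9 nM
- compound 3 `COc1ccc(C2=NN(c3ccccc3)C(c3ccc(OC)cc3)C2O)cc1`: 10.2 nM

In a functional assay on HepG2 cells (Homo sapiens) for antiproliferative activity, read by sulforhodamine B assay, with a stated time of 48 h (on this read-out higher numbers stand for weaker inhibition and lower numbers for stronger inhibition), compound 2 at 9.9 nM and compound 3 at 10.2 nM lie within the scatter of each other. Compound 1 gives a higher number, beyond the scatter from compound 2.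

Compound 4 `COc1cccc(C2=NNC(c3ccc(Br)cc3)C2O)c1` has hydrogen in place of phenyl on an amine nitrogen in a ring. Within the data shown here, no measured pair isolates this change, and the core of compound 1 differs from that of compound 2, so the evidence is thin. Compound 2 and compound 3 both carry this phenyl, and nothing measured shows a number of this order without it. A higher number in this assay, beyond the scatter, is therefore expected, though this remains a judgement.

The estimated step is a 20-fold higher number from compound 2 to compound 4 (1.31 log units; beyond the scatter).

For compound 4 the expected value is 200 nM, with an estimated range of 30 nM to 1500 nM.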

Compound 4, half-maximal inhibitory concentration: 43 nM
Compound 4: middle estimate off by 4.7-fold (0.67 log units), on the high side; the measured number falls inside the stated range.
By their numbers in this assay, from the lowest: compounds 2 and 3 (each within the scatter of the next); then compound 4; then compound 1.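

In this assay, among these compounds, replacing the phenyl with hydrogen on the amine nitrogen in the ring gives a 4.3-fold higher number from compound 2 to compound 4 (0.64 log units; beyond the scatter), the first direct reading of this change on the shared core. The phenyl therefore contributes to the activity here but is not required for it, as compound 4 still gives 43 nM. No available measurement explains the size of this step.

Going by these compounds, it remains open whether a methyl, a benzyl or an acetyl group on this nitrogen would keep the number near that of compound 2 or move it towards that of compound 4. On these data alone, with a single pair, it also remains open whether the same change would give a similar step from compound 3, which carries the same phenyl.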